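Acetylating the Hydrazone Nitrogen of Compound 1

The source may hold more compounds than are shown below. What is called first, only, known or untested is meant among the compounds shown, and "the series" means these compounds.

Compound 1 `CCOC(=O)c1[se]c(N/N=C/c2ccc(Cl)cc2)nc1C`: 52800 nM
Compound 2 `CC(=O)N(/N=C/c1ccc(Cl)cc1)c1nc(-c2ccccc2)c[se]1`: > 62000 nM

Among the measured compounds shown here, in a functional assay on HepG2 cells (Homo sapiens) for cytotoxicity, read by XTT assay, with a stated time of 72 h (on this read-out lower numbers stand for stronger inhibition and higher numbers for weaker inhibition), compound 1 gives 52800 nM and is the only compound with a measured number. Compound 2 reaches only > 62000 nM in this assay, which is a limit of the assay and not a number. For the measured compounds named here, no step between the two has been worked out, so their values are set side by side without a comparison beyond what the figures themselves show; compound 2 carries an acetyl on its hydrazone nitrogen and a different core.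

Compound 3 `CCOC(=O)c1[se]c(N(/N=C/c2ccc(Cl)cc2)C(C)=O)nc1C` keeps the core of compound 1 and differs only in acetyl in place of hydrogen on a nitrogen on an aromatic ring. Going by the values given here, since no measured step of this kind is available, the direction is open; the one acetylated compound sits at the limit of > 62000 nM in this assay, at which 1 of the 2 values shown sits, which hints at weak inhibition. The expected step from compound 1 to compound 3 is a 1.2-fold higher number from compound 1 to compound 3 (0.09 log units; within the scatter), a move that may not exceed the scatter. Compound 3 is estimated at 65000 nM in this assay, from 25000 nM to 180000 nM.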

Compound 3, half-maximal inhibitory concentration: 55200 nM
Estimate against measurement, compound 3: 1.2-fold (0.07 log units) above; measured number inside the range.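

In this assay, acetyl in place of hydrogen on a nitrogen on an aromatic ring gives a 1.0-fold higher number from compound 1 to compound 3 (0.02 log units; within the scatter). On the core of compound 1, hydrogen and acetyl therefore cannot be told apart at this position in this read-out. Compound 3 also gives the first measured number for an acetylated compound, whereas compound 2, with its different core, stands only at a limit of the assay, so acetyl on this nitrogen does not by itself place a compound at that limit: the limit of > 62000 nM in this assay, at which 1 of the 3 values shown sits.

As far as these compounds go, it remains open whether a longer acyl chain, such as butanoyl, or a simple methyl on this nitrogen would also stay within the scatter of compound 1. Also open, from the compounds shown here alone, is what hydrogen in place of acetyl would give on the core of compound 2.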